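Compound 3 to compound 4: pyridin-2-yl in place of phenyl

The compounds below may be only part of what the source reports. "The series", "measured", "known", "first", "only" and "open" are said of these compounds alone.

In a functional assay on NIH3T3 cells (Mus musculus) for inhibition, read by MTT assay, with a stated time of 72 h (a lower number here means a stronger inhibitor, a higher number a weaker inhibitor), compound 3 (`C=C1CC[C@H]2[C@@](C)(CC[C@@H](O)[C@@]2(C)C(=O)OCc2ccccc2)[C@@H]1CCC1=CCOC1=O`) gives 37900 nM and lies within the scatter of both other measured compounds. Compound 1 (`C=C1CC[C@H]2[C@@](C)(CC[C@@H](OC(C)=O)[C@@]2(C)C(=O)OCc2ccccn2)[C@@H]1CCC1=CCOC1=O`) gives 55500 nM and compound 2 (`C=C1CC[C@H]2[C@@](C)(CC[C@@H](O)[C@@]2(C)C(=O)OC)[C@@H]1CCC1=CCOC1=O`) gives 60600 nM so the three numbers form a single group with no order among them.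

Compound 4 (`C=C1CC[C@H]2[C@@](C)(CC[C@@H](O)[C@@]2(C)C(=O)OCc2ccccn2)[C@@H]1CCC1=CCOC1=O`) keeps the core of compound 3 and has pyridin-2-yl in place of phenyl on a saturated chain carbon bound to an oxygen next to a carbonyl group. The same change reads benzyloxycarbonyl to ((pyridin-2-yl)methoxy)carbonyl.

Among the compounds with values here, one measured step bears on this place, phenyl in place of hydrogen, with a 1.6-fold lower number from compound 2 to compound 3 (0.20 log units; within the scatter) and so no move beyond the scatter. Compound 1 already carries the ((pyridin-2-yl)methoxy)carbonyl group and differs elsewhere in its structure, and with 55500 nM it stays within the scatter of compound 3. Nothing beyond the scatter is therefore expected in this assay and the estimated move is a 1.2-fold higher number from compound 3 to compound 4 (0.07 log units; within the scatter) with only a slight upward lean. The estimated value for compound 4 is 45000 nM with an expected range of 23000 nM to 88000 nM in this measurement.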

Compound 4, half-maximal inhibitory concentration: 79800 nM
Compound 4: the middle estimate sits 1.8-fold (0.25 log units) below what was measured, within the range that was stated.
By their numbers in this assay, from the lowest: compounds 3, 1, 2 and 4 (each within the scatter of the next, the first and the last beyond it).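

In this assay, pyridin-2-yl in place of phenyl on a saturated chain carbon bound to an oxygen next to a carbonyl group gives a modest step beyond the scatter (a 2.1-fold higher number from compound 3 to compound 4 (0.32 log units; beyond the scatter)), whereas the earlier step at this place stayed within it (a 1.6-fold lower number from compound 2 to compound 3 (0.20 log units; within the scatter)). Pyridin-2-yl in place of hydrogen at the same place remains within the scatter (a 1.3-fold higher number from compound 2 to compound 4 (0.12 log units; within the scatter)), so at this place the aromatic ring with its nitrogen is separated from phenyl but not from hydrogen. Hydrogen in place of acetyl on an oxygen on a saturated carbon also stays within the scatter (a 1.4-fold higher number from compound 1 to compound 4 (0.16 log units; within the scatter)), which gives the first reading of that oxygen and shows no separation between its two forms in the pyridin-2-yl series.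

Nothing given here explains why pyridin-2-yl and phenyl differ in this way.

On these data alone, whether the step from phenyl to pyridin-2-yl would recur with acetyl on that oxygen remains open, since it rests on a single pair. As far as these compounds go, it is also open how an amine, a carboxylic acid or a longer chain at this place would compare with phenyl and pyridin-2-yl.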